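Estimating compound 3 from two near-level neighbours

A few compounds are considered here, and "the series" means these few. Any claim that something is new, unique, unknown or untested is made for them only; others in the source may bear on it.

In a functional assay on SW-620 cells (Homo sapiens) for inhibition, read by MTT assay, with a stated time of 72 h (a lower number here means a stronger inhibitor, a higher number a weaker inhibitor), compound 2, `COc1cc(NC(C)CCCNC(=O)Nc2ccc(Cl)cc2)c2ncccc2c1`, gives 28000 nM, within the scatter of compound 1, `COc1cc(NC(C)CCCNC(=O)NNC(=O)Nc2ccc(Cl)cc2)c2ncccc2c1`, at 48000 nM. Compound 3, `COc1cc(NC(C)CCCNC(=O)NNC(=O)Nc2ccc(O)cc2)c2ncccc2c1`, has ((4-hydroxyphenyl)carbamoyl)amino in place of 4-chlorophenyl on an amide-type nitrogen. For the measured compounds named here, the one measured step bearing on this is a 1.7-fold lower number from compound 1 to compound 2 (0.23 log units; within the scatter), a similar exchange with the chlorine kept, and it stays within the scatter. Going by the values given here, no measured compound carries the 4-hydroxyphenyl group, so that part of the change has no support. The expected change in this assay is a 1.6-fold higher number from compound 2 to compound 3 (0.21 log units; within the scatter), with nothing expected beyond the scatter. For compound 3 the estimated value is 45000 nM, with an expected range of 20000 nM to 100000 nM.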

Compound 3, half-maximal inhibitory concentration: > 100000 nM
Compound 3: only a limit was reported (the forecaster's own chance of this, stated with the estimate: 15%); middle value at least 2.2-fold (0.34 log units) from the limit.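

Compound 3 is reported in this assay only as a limit: the limit of > 100000 nM in this assay, at which 1 of the 3 values shown sits. With the rest of the molecule unchanged, hydroxy in place of chloro on an aromatic carbon gives an at least 2.0-fold higher number from compound 1 to compound 3 (0.31 log units; beyond the scatter), so this ring substituent moves the number beyond the scatter, which the earlier step of a 1.7-fold lower number from compound 1 to compound 2 (0.23 log units; within the scatter) did not. Exchanging the whole end group gives an at least 3.5-fold higher number from compound 2 to compound 3 (0.55 log units; beyond the scatter), again with hydroxy as the ring substituent.

The true value of compound 3 remains unresolved. Going by these compounds, whether a fluoro or an amine on the same aromatic carbon would stay level with the chloro of compound 1 also stays open.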